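A few compounds are considered here, and "the series" means these few. Any claim that something is new, unique, unknown or untested is made for them only; others in the source may bear on it.

Within the data shown here, compound 3 `COc1cc2c(cc1OC)C(CC(=O)Nc1ccc(Br)cc1)CC2` gives 46.3% in a functional assay on the whole organism (strain Wistar) for inhibition, with Rattus norvegicus as the target, read by paw edema, with a stated time of 6 h, at a dose of 100 mg/kg (on this read-out lower numbers stand for less inhibition and higher numbers for more inhibition at the one dose given (going by the name of the read-out)), the highest number of the three so far; compound 2 `COc1cc2c(cc1OC)C(CC(=O)Nc1ccccc1)CC2`, with 38.9%, lies within the scatter of it, while compound 1 `COc1cc2c(cc1OC)C(CC(=O)O)CC2`, with 20.4%, lies clearly below. The larger steps belong to the change at the carbonyl carbon: a number 18.5 percentage points higher from compound 1 to compound 2 (beyond the scatter) and a number 25.9 percentage points higher from compound 1 to compound 3 (beyond the scatter), whereas the substituent on the aromatic ring of the anilide hardly mattered, a number 7.4 percentage points higher from compound 2 to compound 3 (within the scatter). Compound 4 `COc1cc2c(cc1OC)C(CC(=O)Nc1ccccc1C)CC2` keeps the anilide but changes the group on the amide-type nitrogen: 2-methylphenyl in place of 4-bromophenyl on an amide-type nitrogen. Among the measured compounds shown here, no measured step tests a methyl on that ring, and the bromo step is the only guide, so no change beyond the scatter is expected in this assay. Compound 4 is therefore estimated at 42%, range 30% to 54%, an expected step of a number 4.3 percentage points lower from compound 3 to compound 4 (within the scatter).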

Compound 4, a percentage reported as inhibition, in the whole organism at one dose (the size of the read-out at that dose, not a potency): 25.9%
For compound 4 the middle estimate is 16.1 percentage points above the measured one, and the stated range ends above it.
By their numbers in this assay, from the lowest: compounds 1 and 4 (each within the scatter of the next); then compounds 2 and 3 (each within the scatter of the next).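

In this assay the group on the amide-type nitrogen does matter: methyl in place of hydrogen on the aromatic carbon gives a number 13 percentage points lower from compound 2 to compound 4 (beyond the scatter) and 2-methylphenyl in place of 4-bromophenyl gives a number 20.4 percentage points lower from compound 3 to compound 4 (beyond the scatter) in the same series, both larger than the bromo step suggested. The gain at the carbonyl carbon also does not hold for every anilide, with a number 5.5 percentage points higher from compound 1 to compound 4 (within the scatter) for the (2-methylphenyl)amino change. Nothing at hand explains the lower number.

Open, on these data alone, is whether this number goes with methyl as such or with its place on the ring. As far as these compounds go, how a chloro or a methoxy on that ring, or a benzyl on the amide-type nitrogen, would read also stays open.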